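Imidazole series: benzyl for phenyl, stability outlook

The compounds below may be only part of what the source reports. "The series", "measured", "known", "first", "only" and "open" are said of these compounds alone.

For the measured compounds named here, compound 2 `C[C@H](c1ccccc1)N1C(=O)O[C@](Cc2ccccc2)(c2ncc(-c3ccccc3)[nH]2)C1=O` stands lowest of the two numbers measured in an ADME assay (liver) for metabolic stability, with Liver microsome (Homo sapiens) as the target, using microsomes, with a stated time of 0.5 h, tested at 1 uM (on this read-out lower numbers stand for a less stable compound and higher numbers for a more stable compound), giving 62%; compound 1 `C[C@H](c1ccccc1)N1C(=O)O[C@](Cc2ccccc2)(c2nc(-c3ccccc3)co2)C1=O` gives 73%, and the only measured step is a number 11 percentage points lower from compound 1 to compound 2 (beyond the scatter). Compound 3 `C[C@H](c1ccccc1)N1C(=O)O[C@](Cc2ccccc2)(c2ncc(Cc3ccccc3)[nH]2)C1=O` is not yet measured; it differs from compound 2 by benzyl in place of phenyl on an aromatic carbon. Going by the values given here, no measured step concerns this exchange, since the one known step swaps one five-membered ring for another rather than altering the pendant group. The step is therefore expected to be small and downward at most, a number 7 percentage points lower from compound 2 to compound 3 (within the scatter). Compound 3 is estimated at 55% in this assay, with a range from 35% to 72%.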

Compound 3, percent of the compound remaining: 0%
The estimate for compound 3 lay 55 percentage points above the measured number; measured number outside the range, below it.
By their numbers in this assay, from the lowest: compound 3; then compound 2; then compound 1.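

In this assay, for the compounds shown here, the group on this aromatic carbon next to the ring nitrogen carries far more weight than the one earlier step suggested: benzyl in place of phenyl gives a number 62 percentage points lower from compound 2 to compound 3 (beyond the scatter), against a number 11 percentage points lower from compound 1 to compound 2 (beyond the scatter) for the exchange of the whole five-membered ring. Benzyl has 7 heavy atoms against 6 for phenyl, and both hold the same aromatic ring, so a very small structural change accompanies the full loss. Nothing at hand accounts for this loss.

Still open, as far as these compounds go, is whether the same exchange on compound 1 costs as much. A longer chain or an amine at this carbon could show whether the loss is specific to benzyl.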